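Aryl variation on the triazole nitrogen: compound 4

The source may hold more compounds than are shown below. What is called first, only, known or untested is meant among the compounds shown, and "the series" means these compounds.

The series shares one core, and compound 1 `N#CC1=C(N)Oc2c(c3nc4ccccc4nc3c3ccccc23)C12C(=O)N(Cc1cnnn1-c1ccc(Br)cc1)c1ccccc12` and compound 2 `Cc1cc(C)cc(-n2nncc2CN2C(=O)C3(C(C#N)=C(N)Oc4c3c3nc5ccccc5nc3c3ccccc43)c3ccccc32)c1` differ only in the aryl group on the aromatic nitrogen. In a functional assay on HCT-116 cells (Homo sapiens) for antiproliferative activity, read by MTT assay, with a stated time of 48 h (on this read-out lower numbers stand for stronger inhibition and higher numbers for weaker inhibition), compound 1 gives > 50000 nM, which is a limit of the assay and not a number. In this assay compound 2 gives > 50000 nM, again a limit. The step that the two limits leave unreadable from compound 1 to compound 2 therefore has no readable size, because both of its ends sit at the limit of > 50000 nM in this assay, at which 3 of the 3 values shown sit. Compound 3 `N#CC1=C(N)Oc2c(N)cc3nc4ccccc4nc3c2C12C(=O)N(Cc1cnnn1-c1ccccc1Cl)c1ccccc12` carries an added amine on the core and a 2-chlorophenyl on the aromatic nitrogen. In this assay compound 3 gives > 50000 nM, a limit rather than a number. Compound 3 thus stands exactly where the other two measured values stand, at the limit of > 50000 nM in this assay, at which 3 of the 3 values shown sit, with no number to place it within the series.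

Compound 4 `CCc1cccc(CC)c1-n1nncc1CN1C(=O)C2(C(C#N)=C(N)Oc3c(N)cc4nc5ccccc5nc4c32)c2ccccc21` differs from compound 3 by 2,6-diethylphenyl in place of 2-chlorophenyl on an aromatic nitrogen. Among the measured compounds shown here, the only measured step at this position, a step that the two limits leave unreadable from compound 1 to compound 2, bears on the change but gives no size. No change beyond the scatter is expected from the exchange of aryl groups, so the step of a number no higher from compound 3 to compound 4 (the limit leaves the size open) is estimated as nil. For compound 4 the expected value in this assay is 50000 nM, with a range from 15000 nM to 200000 nM, most probably reported once more as a limit.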

Compound 4, half-maximal inhibitory concentration: 37600 nM
The estimate for compound 4 lay 1.3-fold (0.12 log units) above the measured number; low and high end bracket the measured number.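

Among the compounds shown here, compound 4 is the first compound whose result at the aromatic nitrogen of the triazole is a number and not a limit, so this position can carry a reading inside the range of this assay. On these data alone, with 2,6-diethylphenyl in place of 2-chlorophenyl, the data give an at least 1.3-fold lower number from compound 3 to compound 4 (0.12 log units; that floor lies within the scatter), and the true size of this step stays open since one end is only a limit. The reading is a single one and does not change the overall picture of the series, in which the limit still dominates: the limit of > 50000 nM in this assay, at which 3 of the 4 values shown sit.

The compounds shown leave open whether the two ethyl groups give a number on the core of compound 1, which lacks the added amine, and whether the step from compound 3 to compound 4 goes beyond the scatter. They also leave open what a longer chain such as n-hexyl, or a phenyl ring carrying a carboxylic acid or a dimethylamino group, would give on this nitrogen in place of the aryl groups seen so far.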